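A few compounds are considered here, and "the series" means these few. Any claim that something is new, unique, unknown or untested is made for them only; others in the source may bear on it.

Working notes on the series. The shared core carries the benzimidazole carboxamide of compound 1 `NC(=O)c1ccc2[nH]c(-c3ccc(OC4CCCNC4)cc3)nc2c1`, compound 2 `NC(=O)c1ccc2[nH]c(-c3ccc(OCC4CCCNC4)cc3)nc2c1`, compound 3 `NC(=O)c1ccc2[nH]c(-c3ccc(OCC4CCCN(Cc5ccc(Cl)cc5)C4)cc3)nc2c1` and the unmeasured compound 4 `CC(=O)N1CCC(CCOc2ccc(-c3nc4cc(C(N)=O)ccc4[nH]3)cc2)CC1`. The read-out is a physicochemical assay for solubility, with a stated time of 3 days, at pH 7; on this read-out lower numbers stand for lower solubility and higher numbers for higher solubility. In this assay compound 1 gives only a limit, > 400000 nM, with the limit of > 400000 nM in this assay, at which 1 of the 3 values shown sits, marking that the value is a limit and not a number. In this assay compound 2 stands without a number, recorded as "not determined" (no result reported), and compound 3 likewise as "not determined" (no result reported). Compound 2 therefore has no place on the numbers shown; the only measured entry in the set is the limit of compound 1.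

The step to compound 4 is (1-acetylpiperidin-4-yl)methyl in place of piperidin-3-yl on a saturated chain carbon bound to an oxygen on an aromatic ring. For the measured compounds named here, no measured step between any two compounds of the set exists, so nothing here sizes the change. The expectation for this assay is a step downward from the region where compound 1 sits, of moderate size beyond the scatter, though the absence of a number for compound 2 leaves this open. Compound 4 is estimated at 60000 nM, within 10000 nM to 400000 nM.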

Compound 4, solubility: 2000 nM
For compound 4 the middle estimate is 30-fold (1.48 log units) above the measured one; measured number outside the range, below it.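

No step can be read from compound 2 to compound 4 in this assay, as the entries shown for this pair allow no comparison. The compounds shown leave open what the change to (1-acetylpiperidin-4-yl)methyl alone does to the read-out in this assay.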